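A substituent exchange on the aromatic oxygen

The compounds below may be only part of what the source reports. "The series", "measured", "known", "first", "only" and "open" are said of these compounds alone.

Compound 1 `CCCCOc1ccc2oc(/C=C/[S+](C)[O-])cc(=O)c2c1` and compound 2 `C[S+]([O-])/C=C/c1oc2ccccc2c(=O)c1Cc1ccccc1` have been measured in a functional assay on DLD-1 cells (Homo sapiens) for cytotoxicity, with a stated time of 48 h; a lower number here means a stronger inhibitor, a higher number a weaker inhibitor. Compound 1 gives 4800 nM there, and compound 2 gives 5100 nM. Within the data shown here, these two numbers lie within the scatter of each other, so compound 1 cannot be set apart from compound 2 on what has been measured, and the series so far shows a single level of potency. Compound 3 `C[S+]([O-])/C=C/c1cc(=O)c2cc(OC(=O)C(C)(C)C)ccc2o1` has not yet been measured in this assay. It differs from compound 1 in one place: (tert-butyl)carbonyl in place of butyl on an oxygen on an aromatic ring. Among the measured compounds shown here, no step between two measured compounds matches this change, so there is nothing in the data to point the step in either direction. The step of a 1.0-fold higher number from compound 1 to compound 3 (0.02 log units; within the scatter) is expected to stay within the scatter, with no clear direction. Compound 3 is therefore estimated at 5000 nM, with a range from 2000 nM to 13000 nM.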

Compound 3, half-maximal inhibitory concentration: 8000 nM
Compound 3: the middle estimate sits 1.6-fold (0.20 log units) below what was measured; low and high end bracket the measured number.
By their numbers in this assay, from the lowest: compounds 1, 2 and 3 (each within the scatter of the next).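

On the oxygen on an aromatic ring, exchanging butyl for (tert-butyl)carbonyl gives in this assay a 1.7-fold higher number from compound 1 to compound 3 (0.22 log units; within the scatter), so the two groups cannot be set apart at this position. Among these compounds, this is the first single-place step, and it shows that a group with a carbonyl and a hydrogen-bond acceptor, neither of which butyl has, can enter here without a change that exceeds the scatter. No measured evidence bears on this result.

From the compounds shown here alone, whether any group on this oxygen can move the number beyond the scatter remains open, for example a longer chain than butyl, an amine-bearing chain or a carboxylic acid. This single pair also leaves open whether the same exchange would read alike on another core.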